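Moving the Ring Oxygen and Losing the Hydroxyl

A few compounds are considered here, and "the series" means these few. Any claim that something is new, unique, unknown or untested is made for them only; others in the source may bear on it.

Compound 1, `N#Cc1cnc(NCc2cnccc2C(F)(F)F)cc1N[C@H]1CC[C@H](O)CC1`: 350 nM
Compound 2, `N#Cc1cnc(NCc2cnccc2C(F)(F)F)cc1NC[C@H]1CC[C@H](O)CC1`: 50 nM

In an assay on isolated protein for inhibition of protein kinase C theta type (Homo sapiens), read by TR-FRET, with a stated time of 2 h (on this read-out higher numbers stand for weaker inhibition and lower numbers for stronger inhibition), compound 2 gives the lower of the two numbers; compound 1 gives the higher one, and the step of a 7.0-fold lower number from compound 1 to compound 2 (0.85 log units; beyond the scatter) lies beyond the scatter. Compound 3, `N#Cc1cnc(NCc2cnccc2C(F)(F)F)cc1NCCC1CCOCC1`, carries (oxan-4-yl)methyl in place of 4-hydroxycyclohexyl on a saturated chain carbon bound to a nitrogen on an aromatic ring. Among the compounds with values here, only the step from compound 1 to compound 2 bears on this change, and only partly: it shows that lengthening the link to the nitrogen by one saturated carbon lowered the number. Within the data shown here, the new change lengthens that link once more, but it also replaces the six-membered ring of carbon only, with its hydroxyl, by a ring with one hetero atom and no hydrogen-bond donor, and no measured pair shows that exchange. The expectation is therefore uncertain, leaning toward a somewhat higher number: for compound 3 the estimate is 110 nM, within 30 nM to 450 nM, which is an expected step of a 2.2-fold higher number from compound 2 to compound 3 (0.34 log units; beyond the scatter).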

Compound 3, half-maximal inhibitory concentration: 1200 nM
Compound 3: middle estimate off by 11-fold (1.04 log units), on the low side; the whole stated range lies below it.
By their numbers in this assay, from the lowest: compound 2; then compound 1; then compound 3.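

In this assay, putting 2-(oxan-4-yl)ethyl in place of (4-hydroxycyclohexyl)methyl gives a 24-fold higher number from compound 2 to compound 3 (1.38 log units; beyond the scatter) and so reverses the gain seen earlier at this position. Compared with the directly attached 4-hydroxycyclohexyl group, the same 2-(oxan-4-yl)ethyl group gives a 3.4-fold higher number from compound 1 to compound 3 (0.54 log units; beyond the scatter) and leaves compound 3 with the highest number of the three. No measurement shown here accounts for this loss.

Compound 3 has both a longer chain and a different ring, with no hydroxyl, so these compounds cannot show how much of the loss belongs to each change. A 2-(4-hydroxycyclohexyl)ethyl group would keep the hydroxyl-bearing ring on the longer chain, and (oxan-4-yl)methyl would put the oxygen-containing ring on the shorter one, which would help to separate the two changes.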